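Replacing the Cyclopropylethynyl Group of Compound 2

The source may hold more compounds than are shown below. What is called first, only, known or untested is meant among the compounds shown, and "the series" means these compounds.

Compound 1 (`Cc1cc(Br)cc(C)c1Oc1ccc(N)c(Nc2ccc(C#N)cc2)n1`) gives 15500 nM in an ADME assay on TZM cells (Homo sapiens) for cytotoxicity, read by XTT assay, with a stated time of 4 days (on this read-out higher numbers stand for lower toxicity in this test and lower numbers for higher toxicity in this test), while compound 2 (`Cc1cc(C#CC2CC2)cc(C)c1Oc1ccc(N)c(Nc2ccc(C#N)cc2)n1`) gives 7450 nM as the lower of these two numbers. Compound 3 (`Cc1cc(/C=C/C(=O)O)cc(C)c1Oc1ccc(N)c(Nc2ccc(C#N)cc2)n1`) carries 2-carboxyethenyl in place of 2-cyclopropylethynyl on an aromatic carbon. Going by the values given here, the only measured step at this carbon is modest (a 2.1-fold lower number from compound 1 to compound 2 (0.32 log units; beyond the scatter)) and a single step is thin evidence. A step of about that size is therefore expected in this assay toward a higher number (a 2.7-fold higher number from compound 2 to compound 3 (0.43 log units; beyond the scatter)). For compound 3 the expected value is 20000 nM (range 8000 nM to 60000 nM).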

Compound 3, half-maximal cytotoxic concentration: 18000 nM
For compound 3 the middle estimate is 1.1-fold (0.05 log units) above the measured one, within the range that was stated.
By their numbers in this assay, from the lowest: compound 2; then compounds 1 and 3 (each within the scatter of the next).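

In this assay, 2-carboxyethenyl in place of 2-cyclopropylethynyl gives a 2.4-fold higher number from compound 2 to compound 3 (0.38 log units; beyond the scatter), so a change at this aromatic carbon can also move the number toward lower toxicity in this test. Against bromo, 2-carboxyethenyl gives a 1.2-fold higher number from compound 1 to compound 3 (0.06 log units; within the scatter), so these two groups cannot be told apart here. Nothing measured here gives a reason for either step.

Going by these compounds, what a methyl ester or an amide would give at this carbon stays open, and with it whether the carboxylic acid itself matters for this read-out.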